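Adding a Methoxy to Compound 2

A few compounds are considered here, and "the series" means these few. Any claim that something is new, unique, unknown or untested is made for them only; others in the source may bear on it.

Compound 1 `COc1ccc(CNc2ncnc3c2ncn3C2CCCCO2)c(OC)c1`: > 25000 nM (a limit)
Compound 2 `COc1cccc(OC)c1CNc1ncnc2c1ncn2C1CCCCO1`: > 100000 nM (a limit)

In an ADME assay on MCF7 cells (Homo sapiens) for cytotoxicity, with a stated time of 72 h (on this read-out lower numbers stand for stronger inhibition and higher numbers for weaker inhibition), compound 2 is known only by a limit, > 100000 nM, and no actual number has been measured for it. Compound 1 likewise gives only a limit, > 25000 nM. Compound 3 `COc1cc(OC)c(CNc2ncnc3c2ncn3C2CCCCO2)c(OC)c1` differs from compound 2 in one place: methoxy in place of hydrogen on an aromatic carbon. Neither compound has a measured number to suggest real inhibition, so only a small move toward stronger inhibition is expected, with the estimated step of an at least 1.4-fold lower number from compound 2 to compound 3 (0.15 log units; that floor lies within the scatter). Compound 3 is expected at 70000 nM, within an estimated range of 20000 nM to 150000 nM.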

Compound 3, half-maximal inhibitory concentration: > 50000 nM
Compound 3 gave a limit, no number; the forecaster's own chance of this, stated with the estimate: 85%; the middle value is on the limit's open side.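

With only limits for compound 1, compound 2 and compound 3, neither the step from compound 2 to compound 3 nor the step from compound 1 to compound 3 can be read. Going by these compounds, what the added methoxy changes in this assay stays open.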